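This account rests on a few compounds, and the source may have more. Where it says the series, first, only, none or still open, it means among the compounds named here.

Among the measured compounds shown here, in a functional assay on A549 cells (Homo sapiens) for antiproliferative activity, read by sulforhodamine B assay, with a stated time of 3 days (a higher number here means a weaker inhibitor of growth, a lower number a stronger inhibitor of growth), compound 3 `CN1CCC(C(=O)Nc2cccc(Nc3ncc(F)c(Nc4ccc(F)cc4)n3)c2)CC1` gives 1330 nM, the only plain number in the set. Compound 1 `O=C(Nc1nccs1)c1cccc(Nc2ncc(F)c(Nc3ccc(F)cc3)n2)c1` reports only a limit, > 10000 nM. Compound 2 `O=C(Nc1ccc(C(F)(F)F)cc1)c1cccc(Nc2ncc(F)c(Nc3ccc(F)cc3)n2)c1` likewise reports only a limit, > 10000 nM. Compound 4 `CN(C)CC(=O)Nc1cccc(Nc2ncc(F)c(Nc3ccc(F)cc3)n2)c1` has (dimethylamino)methyl in place of 1-methylpiperidin-4-yl on a carbonyl carbon. Two measured steps come nearest. One is an at least 7.5-fold lower number from compound 1 to compound 3 (0.87 log units; beyond the scatter), which changes far more than this swap does, and the other is a step that the two limits leave unreadable from compound 1 to compound 2. Neither tests this place, so the expectation rests on compound 3 at 1330 nM and on the single nitrogen kept in both groups. The expected change is small, within the scatter: a 1.5-fold higher number from compound 3 to compound 4 (0.18 log units; within the scatter). For compound 4 the estimate is 2000 nM, with an expected range of 700 nM to 6000 nM.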

Compound 4, concentration for 50% growth inhibition: 1180 nM
The estimate for compound 4 lay 1.7-fold (0.23 log units) above the measured number; the range from low to high includes it.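

In this assay, (dimethylamino)methyl in place of 1-methylpiperidin-4-yl on the carbonyl carbon gives a 1.1-fold lower number from compound 3 to compound 4 (0.05 log units; within the scatter), so at this position the ring can go, and the heavy atoms fall in number, with no readable change. The open-chain group also gives an at least 8.4-fold lower number from compound 1 to compound 4 (0.92 log units; beyond the scatter). That step is only a bound, as compound 1 reports a limit and not a number: the limit of > 10000 nM in this assay, at which 2 of the 4 values shown sit.

The compounds shown leave open what happens when a cyclohexyl group, which has no nitrogen, sits at this carbonyl carbon. They also leave open the effect of a longer chain carrying the dimethylamino group.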